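A Third Methoxy on the Benzylic Ring

The compounds below may be only part of what the source reports. "The series", "measured", "known", "first", "only" and "open" are said of these compounds alone.

Going by the values given here, compound 2 `COc1ccc(CNc2nc3cc(N)cc(N)c3nc2-c2ccccc2)cc1OC` stands at the higher of the two numbers so far in a functional assay on Hs-578T cells (Homo sapiens) for inhibition, read by sulforhodamine B assay, with a stated time of 48 h (a higher number here means a weaker inhibitor of growth, a lower number a stronger inhibitor of growth), where compound 2 gives 33900 nM. Among the compounds with values here, its only neighbour, compound 1 `Nc1cc(N)c2nc(-c3ccccc3)c(NCc3ccc(Cl)c(Cl)c3)nc2c1`, gives 5890 nM in this assay, and the one measured step, a 5.8-fold higher number from compound 1 to compound 2 (0.76 log units; beyond the scatter), came from exchanging the 3,4-dichlorophenyl for the 3,4-dimethoxyphenyl on the saturated chain carbon bound to a nitrogen on an aromatic ring. Compound 3 `COc1cc(CNc2nc3cc(N)cc(N)c3nc2-c2ccccc2)cc(OC)c1OC` differs from compound 2 by methoxy in place of hydrogen on an aromatic carbon. Within the data shown here, no measured step matches this change; the step of a 5.8-fold higher number from compound 1 to compound 2 (0.76 log units; beyond the scatter) concerns the same ring but a different exchange, so it serves only as a loose guide. Adding a further methoxy to a ring that already carries methoxy groups is expected to move the number little in this assay, so the step of a 1.0-fold higher number from compound 2 to compound 3 (0.01 log units; within the scatter) is expected to stay near the scatter. For compound 3 the estimate in this assay is 35000 nM, ranging from 15000 nM to 80000 nM.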

Compound 3, concentration for 50% growth inhibition: 3020 nM
For compound 3 the middle estimate is 12-fold (1.06 log units) above the measured one, outside the stated range (below it).
By their numbers in this assay, from the lowest: compounds 3 and 1 (each within the scatter of the next); then compound 2.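

In this assay, methoxy in place of hydrogen on the aromatic carbon ortho to a methoxy group and meta to a large group gives an 11-fold lower number from compound 2 to compound 3 (1.05 log units; beyond the scatter) and so counts as a large step. The earlier compounds shown here showed only an exchange of the groups on this ring, whereas this step shows that a further methoxy at this position, added to the dimethoxyphenyl ring, can by itself change the number by more than the scatter. No available evidence accounts for the size of this step.

The compounds shown leave open whether a hydroxy, an ethoxy or a chlorine on this same aromatic carbon would give a comparable step. They also leave open whether the step depends on the methoxy groups already on the ring, as the same addition to the 3,4-dichlorophenyl ring of compound 1 would test.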